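The source may hold more compounds than are shown below. What is called first, only, known or untested is meant among the compounds shown, and "the series" means these compounds.

Working notes on the cytotoxicity series.

Compound 3 `CSc1cccc(NC(=O)c2cccc(/C=C3\CC(=O)N(c4ccccc4)C3=O)c2)c1` stands where every measured member of the series stands. In an ADME assay on NCM460 cells (Homo sapiens) for cytotoxicity, read by MTT assay, with a stated time of 72 h (a higher number here means a weaker inhibitor, a lower number a stronger inhibitor), compound 3 gives > 100000 nM, which is a limit of the assay and not a number. Compound 1 `O=C(Nc1cccc(F)c1)c1cccc(/C=C2\CC(=O)N(c3ccccc3)C2=O)c1` gives > 100000 nM in this assay, likewise a limit. Compound 2 `O=C(NCC1CCCCC1)c1cccc(/C=C2\CC(=O)N(c3ccccc3)C2=O)c1` gives > 100000 nM, again a limit. Because (the limit of > 100000 nM in this assay, at which 3 of the 3 values shown sit), none of the steps among these three can be read: the step that the two limits leave unreadable from compound 1 to compound 2, the step that the two limits leave unreadable from compound 1 to compound 3 and the step that the two limits leave unreadable from compound 2 to compound 3 all fall between two limits, so their size and direction stay unknown.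

Compound 4 `CCOc1ccc(NC(=O)c2cccc(/C=C3\CC(=O)N(c4ccccc4)C3=O)c2)cc1` is not yet measured. The change from compound 3 is 4-ethoxyphenyl in place of 3-(methylsulfanyl)phenyl on an amide-type nitrogen. Going by the values given here, no measured step bears on this change in a readable way; what the three measured steps do show is that changing the group on the amide-type nitrogen, in either direction, has left every compound at the limit of this assay. On that basis the step from compound 3 to compound 4 is expected to be a step that the limit leaves unreadable from compound 3 to compound 4, meaning no shift beyond the scatter. Compound 4 is therefore estimated at 150000 nM in this assay, with a range from 60000 nM to 400000 nM, and most likely reported only as a limit.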

Compound 4, half-maximal inhibitory concentration: > 100000 nM
Compound 4 ended at the assay's limit (the forecaster's own chance of this, stated with the estimate: 85%); the middle value is on the limit's open side.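

On these data alone, no new step can be read: the steps to compound 4 from compound 1, compound 2 and compound 3 all fall between two limits in this assay, so their size and direction stay unknown. The compounds shown leave open whether any group on the amide-type nitrogen gives a measurable value in this assay.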